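Oxime replaced by ketone: expectation for compound 4

A few compounds are considered here, and "the series" means these few. Any claim that something is new, unique, unknown or untested is made for them only; others in the source may bear on it.

Compound 3 `C=CCn1c(SC/C(=N/O)c2ccccc2)nnc1-c1ccc(OC)cc1` gives 57% in a functional assay on the whole organism (strain albino) for inhibition, with Rattus norvegicus as the target, read by paw edema, with a stated time of 5 h, at a dose of 0.28 mmol/kg by the oral route; a higher number here means more inhibition at the dose given (going by the name of the read-out), a lower number less inhibition. Compound 1 `C=CCn1c(SCC(=O)c2ccccc2)nnc1-c1ccccc1` gives 66% in this assay, and compound 2 `C=CCn1c(SCC(=O)c2ccccc2)nnc1-c1ccc(OC)c(OC)c1` gives 62%. Compound 3 stands lowest of the three numbers, nearest to compound 2 and furthest from compound 1, yet both gaps lie within the scatter, so no order among the three can be read from these values.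

Compound 4 `C=CCn1c(SCC(=O)c2ccccc2)nnc1-c1ccc(OC)cc1` has not yet been measured. It differs from compound 3 in one place: a group of 8 heavy atoms (7 carbon, 1 oxygen; one six-membered aromatic ring of carbon only) in place of a group of 9 heavy atoms (7 carbon, 1 nitrogen, 1 oxygen; one six-membered aromatic ring of carbon only), on a saturated chain carbon bound to a sulfur. The entering benzoyl group, on a saturated chain carbon bound to a sulfur, is also present in compound 1 and in compound 2, both of which sit within the scatter of compound 3.

Within the data shown here, no step between measured compounds is available to calibrate this change. Because compound 1 gives 66% and compound 2 gives 62% with benzoyl in that place, the step is expected to be small, upward if anything, and not beyond the scatter: a number 5 percentage points higher from compound 3 to compound 4 (within the scatter). For compound 4 the expected value in this assay is 62%, with a range from 52% to 72%.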

Compound 4, a percentage reported as inhibition, in the whole organism at one dose (the size of the read-out at that dose, not a potency): 61%
For compound 4 the middle estimate is 1 percentage points above the measured one, and the stated range covers the measured number.
By their numbers in this assay, from the lowest: compounds 3, 4, 2 and 1 (each within the scatter of the next).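

In this assay, benzoyl in place of the oxime-bearing group, on a saturated chain carbon bound to a sulfur, gives a number 4 percentage points higher from compound 3 to compound 4 (within the scatter) and so shows that this position accepts either group without a step beyond the scatter. With benzoyl held in that place, hydrogen in place of methoxy on an aromatic carbon gives a number 1 percentage points lower from compound 2 to compound 4 (within the scatter) and methoxy in place of hydrogen on an aromatic carbon gives a number 5 percentage points lower from compound 1 to compound 4 (within the scatter) so neither methoxy change separates these compounds at this single dose. No measurement at hand offers a reason for these small steps.

Open, on these data alone, is whether an amine, a carboxylic acid or a longer chain on that saturated carbon would give a step beyond the scatter. A single dose and time also leave potency in this series unread.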